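Removing the Phenolic Hydroxyl from a Naphthyl Polyamine

A few compounds are considered here, and "the series" means these few. Any claim that something is new, unique, unknown or untested is made for them only; others in the source may bear on it.

Compound 3 `Oc1ccccc1CNCCCNCCCCNCCCNCc1ccc2ccccc2c1O` gives 1860 nM in an assay for binding affinity to heparin (Homo sapiens), read by surface plasmon resonance (a higher number here means weaker binding, a lower number tighter binding), the lowest of the three numbers measured. Compound 2 `Oc1ccccc1CNCCCNCCCCNCCCNCc1c(O)ccc2ccccc12` gives 2620 nM, and the step of a 1.4-fold lower number from compound 2 to compound 3 (0.15 log units; within the scatter) lies within the scatter. Compound 1 `Oc1ccccc1CNCCCNCCCCNCCCNCc1ccccc1O` gives 21500 nM; the steps of an 8.2-fold lower number from compound 1 to compound 2 (0.91 log units; beyond the scatter) and a 12-fold lower number from compound 1 to compound 3 (1.06 log units; beyond the scatter) are both beyond the scatter. Compound 4 `Oc1ccccc1CNCCCNCCCCNCCCNCc1cccc2ccccc12` differs from compound 3 by naphthalen-1-yl in place of 1-hydroxynaphthalen-2-yl on a saturated chain carbon bound to an amine nitrogen. Going by the values given here, no measured step removes a hydroxyl: the two large steps exchange a single ring for two fused rings, which compound 4 keeps, and the step of a 1.4-fold lower number from compound 2 to compound 3 (0.15 log units; within the scatter) merely relocates the hydroxyl. Among the compounds with values here, with no direct precedent, the step of a 1.9-fold higher number from compound 3 to compound 4 (0.27 log units; within the scatter) is expected to be small to modest, toward a higher number. Compound 4 is therefore estimated at 3500 nM, with a range of 1200 nM to 12000 nM.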

Compound 4, dissociation constant: 1890 nM
The estimate for compound 4 lay 1.9-fold (0.27 log units) above the measured number; measured number inside the range.
By their numbers in this assay, from the lowest: compounds 3, 4 and 2 (each within the scatter of the next); then compound 1.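

In this assay the ring hydroxyl proves dispensable at this place: the steps of a 1.0-fold higher number from compound 3 to compound 4 (0.01 log units; within the scatter) and a 1.4-fold lower number from compound 2 to compound 4 (0.14 log units; within the scatter) both stay within the scatter. The step of an 11-fold lower number from compound 1 to compound 4 (1.06 log units; beyond the scatter) shows that the large drop from the 2-hydroxyphenyl compound survives without that hydroxyl, so among these compounds it goes with the two fused rings. No evidence is available to explain why the hydroxyl makes no measurable difference here. Open, as far as these compounds go, is whether a plain phenyl ring at this place would behave like 2-hydroxyphenyl, and whether an amine on the naphthalene would change the number.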